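The source may report more compounds than this note shows. Statements on the series, on what has been measured and on what is new or still open speak of the compounds shown alone.

Compound 2, `COc1ccc(Cn2cc(CO/N=C/c3c(-c4ccc(C)cc4)nc4c(C)cccn34)nn2)cc1`, was tested in a functional assay on the whole organism (strain NMRI) with Mus musculus as the target, with a stated time of 0.5 h (on this read-out lower numbers stand for an effect already at smaller amounts and higher numbers for an effect only at larger amounts of compound), and gives 40 mg/kg. It stands level with compound 1, `COc1ccc(Cn2cc(CO/N=C/c3c(-c4ccccc4)nc4c(C)cccn34)nn2)cc1`, which in this assay gives 40 mg/kg; the step of no change at the digits printed from compound 1 to compound 2 (within the scatter) lies within the scatter. The next compound, compound 3, `Cc1ccc(-c2nc3c(C)cccn3c2/C=N/OCc2cn(Cc3ccc([N+](=O)[O-])cc3)nn2)cc1`, differs from compound 2 by nitro in place of methoxy on an aromatic carbon. For the measured compounds named here, no measured step touches this part of the molecule, so the one step known is only a hint that small changes leave the dose alone. Compound 3 is therefore expected to give 40 mg/kg, somewhere between 20 mg/kg and 80 mg/kg, meaning an expected step of no change at the digits printed from compound 2 to compound 3 (within the scatter).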

Compound 3, minimum effective dose: 20 mg/kg
Beside the measured number, compound 3's estimate is 2.0-fold (0.30 log units) above it; the measured number falls inside the stated range.
By their numbers in this assay, from the lowest: compounds 3, 1 and 2 (each within the scatter of the next).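

In this assay, 4-nitrobenzyl in place of 4-methoxybenzyl gives a 2.0-fold lower number from compound 2 to compound 3 (0.30 log units; within the scatter). For the compounds shown here, the only earlier step lay elsewhere in the molecule, so this is the first reading at this position, para to a large group, and here methoxy and nitro cannot be told apart. No available evidence accounts for this result.

Open, going by these compounds, is how an amine, a carboxylic acid or a longer chain would behave at this position. A single pair also cannot show whether the same holds on other versions of the molecule.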